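A few compounds are considered here, and "the series" means these few. Any claim that something is new, unique, unknown or untested is made for them only; others in the source may bear on it.

In an assay on isolated protein for inhibition of coagulation factor X (Oryctolagus cuniculus), tested at 1 uM (a higher number here means more inhibition at the concentration tested (going by the name of the read-out), a lower number less inhibition), compound 3 `O=C1[C@@H](NS(=O)(=O)c2ccc(-c3ccon3)s2)CCN1Cc1cc2[nH]cccc-2n1` gives 31%. Compound 1 `O=C1[C@@H](NS(=O)(=O)c2ccc(-c3ccon3)s2)CCN1Cc1cc2c[nH]ccc-2n1` differs from it by a group of 9 heavy atoms (7 carbon, 2 nitrogen; one five-membered aromatic ring with 1 hetero atom, one six-membered aromatic ring with 1 hetero atom) in place of a group of 9 heavy atoms (7 carbon, 2 nitrogen; one five-membered aromatic ring with 1 hetero atom, one six-membered aromatic ring with 1 hetero atom), on a saturated chain carbon bound to an amide-type nitrogen in a ring, and in this assay compound 1 gives 17%, a step of a number 14 percentage points lower from compound 3 to compound 1 (beyond the scatter). Compound 2 `CC(C)(C)c1ccc(S(=O)(=O)N[C@H]2CCN(Cc3cc4[nH]cccc-4n3)C2=O)cc1` carries a different group on the sulfonyl sulfur: 4-(tert-butyl)phenyl in place of 5-(1,2-oxazol-3-yl)thiophen-2-yl on a sulfonyl sulfur. In this assay compound 2 gives 22%, and the step of a number 9 percentage points higher from compound 2 to compound 3 (within the scatter) lies within the scatter, so these two values show no order between them. Compound 4 `CC(C)(C)c1ccc(S(=O)(=O)N[C@H]2CCN(Cc3cc4c[nH]ccc-4n3)C2=O)cc1` has not yet been measured in this assay. It differs from compound 2 by a group of 9 heavy atoms (7 carbon, 2 nitrogen; one five-membered aromatic ring with 1 hetero atom, one six-membered aromatic ring with 1 hetero atom) in place of a group of 9 heavy atoms (7 carbon, 2 nitrogen; one five-membered aromatic ring with 1 hetero atom, one six-membered aromatic ring with 1 hetero atom), on a saturated chain carbon bound to an amide-type nitrogen in a ring, which is the same change as that from compound 3 to compound 1, made here on the core of compound 2 rather than the core of compound 3. Since compound 2 gives 22% and the same change earlier produced a number 14 percentage points lower from compound 3 to compound 1 (beyond the scatter), the step to compound 4 is expected to be of similar size, a number 13 percentage points lower from compound 2 to compound 4 (beyond the scatter), an expectation resting on that single earlier instance. Compound 4 is therefore estimated to give 9% in this assay, with a likely range from 0% to 20%.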

Compound 4, a percentage reported as inhibition, at one concentration (the size of the read-out at that concentration, not a potency): 14%
Beside the measured number, compound 4's estimate is 5 percentage points below it; the measured number falls inside the stated range.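

In this assay, the exchange of the two groups on a saturated chain carbon bound to an amide-type nitrogen in a ring gives steps on the two cores that do not differ: the same change on two cores in this assay, a number 14 percentage points lower (beyond the scatter) from compound 3 to compound 1 and a number 8 percentage points lower (within the scatter) from compound 2 to compound 4, 6 percentage points apart, within the scatter of two such steps. The exchange on the sulfonyl sulfur between 4-(tert-butyl)phenyl and 5-(1,2-oxazol-3-yl)thiophen-2-yl likewise carries over without a measurable difference: the same change on two cores in this assay, a number 9 percentage points higher (within the scatter) from compound 2 to compound 3 and a number 3 percentage points higher (within the scatter) from compound 4 to compound 1, 6 percentage points apart, within the scatter of two such steps. Among these compounds, this is agreement across only two cores, however, and it does not fix the size of either change, since the new step, a number 8 percentage points lower from compound 2 to compound 4 (within the scatter), does not by itself establish an order, and neither does a number 3 percentage points lower from compound 1 to compound 4 (within the scatter).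

The compounds shown leave open whether the ring exchange holds with other groups on the sulfonyl sulfur, such as a 4-chlorophenyl, or an aryl ring carrying an amine or a carboxylic acid. They also leave open how these readings at a single concentration relate to potency.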